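A few compounds are considered here, and "the series" means these few. Any claim that something is new, unique, unknown or untested is made for them only; others in the source may bear on it.

In a functional assay on PC-3 cells (Homo sapiens) for inhibition (on this read-out lower numbers stand for stronger inhibition and higher numbers for weaker inhibition), compound 1 `COc1cc2nc(N3CCN(S(=O)(=O)c4ccc(Br)cc4)CC3)nc(N)c2cc1OC` gives 20000 nM, the lowest of the two numbers measured. Among the measured compounds shown here, compound 2 `COc1cc2nc(N3CCN(S(=O)(=O)c4ccc(C(=O)O)cc4)CC3)nc(N)c2cc1OC` gives 53000 nM in this assay, and the only single-point step known, a 2.7-fold higher number from compound 1 to compound 2 (0.42 log units; beyond the scatter), is modest. Compound 3 `COc1cc2nc(N3CCN(S(=O)(=O)c4cc(F)c(Cl)c(C(=O)O)c4)CC3)nc(N)c2cc1OC` has not been measured; its change from compound 1 is 3-carboxy-4-chloro-5-fluorophenyl in place of 4-bromophenyl on a sulfonyl sulfur. The step from compound 1 to compound 2 bears on it, since a carboxy enters in both cases. A similar weakening is therefore expected, a 2.3-fold higher number from compound 1 to compound 3 (0.35 log units; beyond the scatter), so compound 3 is estimated at 45000 nM in this assay, in the range 15000 nM to 130000 nM.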

Compound 3, half-maximal inhibitory concentration: 56000 nM
Compound 3: middle estimate off by 1.2-fold (0.09 log units), on the low side, and the stated range covers the measured number.
By their numbers in this assay, from the lowest: compound 1; then compounds 2 and 3 (each within the scatter of the next).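

The step of a 2.8-fold higher number from compound 1 to compound 3 (0.45 log units; beyond the scatter) in this assay shows that the weakening seen with 4-carboxyphenyl also appears with a more substituted carboxy-bearing ring on the sulfonyl sulfur. The step of a 1.1-fold higher number from compound 2 to compound 3 (0.02 log units; within the scatter) shows that the two carboxy-bearing rings cannot be told apart here, despite their different substitution. No measured evidence explains this result.
The compounds shown leave open whether a methyl ester or a primary amide in place of the carboxy would give numbers like those of compound 1 or compound 3. They also leave open what chloro or fluoro would do alone.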